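Phenyl for furan-2-yl on the shared pyridine-type core

This account rests on a few compounds, and the source may have more. Where it says the series, first, only, none or still open, it means among the compounds named here.

compound 1 `Oc1cccc(-c2cc(-c3ccccc3)nc(-c3ccc(Cl)cc3)c2)c1` in a functional assay on DU-145 cells (Homo sapiens) for cytotoxicity, read by CCK-8 assay and cell counting, with a stated time of 2 days (on this read-out lower numbers stand for stronger inhibition and higher numbers for weaker inhibition), gives 11200 nM
compound 2 `Oc1cccc(-c2cc(-c3ccc(Cl)cc3)nc(-c3ccco3)c2)c1` in this assay gives 11400 nM
compound 3 `Oc1ccc(-c2cc(-c3cccc(Cl)c3)nc(-c3ccco3)c2)cc1` in this assay gives 5750 nM

Of the compounds shown here, three have been measured; a fourth, compound 4 `Oc1ccc(-c2cc(-c3ccccc3)nc(-c3cccc(Cl)c3)c2)cc1`, has not. Compounds 2 and 3 share their atoms but join them differently; the difference between the two cores is not broken down here.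

Going by the values given here, the one change measured so far is the step from compound 2 to compound 1: phenyl in place of furan-2-yl on an aromatic carbon. In this assay it gave a 1.0-fold lower number from compound 2 to compound 1 (0.01 log units; within the scatter), so no shift attributable to the change is visible in that pair.

The same kind of change separates compound 3 from compound 4: phenyl in place of furan-2-yl on an aromatic carbon. The surroundings of the place are not the same word for word: in compound 2 the site is meta to a 3-hydroxyphenyl group and meta to a 4-chlorophenyl group, while in compound 3 it is meta to a 3-chlorophenyl group and meta to a 4-hydroxyphenyl group. The hydroxyl and chlorine therefore sit on different positions of the two flanking rings.

The expectation for compound 4 rests on a single measured pair, and it is worded as an expectation only. Compound 4 is expected to show a 1.0-fold higher number from compound 3 to compound 4 (0.02 log units; within the scatter) in this assay, because the earlier pair gave a 1.0-fold lower number from compound 2 to compound 1 (0.01 log units; within the scatter). Compound 4 is estimated at 6000 nM, with a range from 2500 nM to 14000 nM.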

Compound 4, half-maximal inhibitory concentration: 5360 nM
Compound 4: the middle estimate sits 1.1-fold (0.05 log units) above what was measured; the range from low to high includes it.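

In this assay, phenyl in place of furan-2-yl gave a 1.1-fold lower number from compound 3 to compound 4 (0.03 log units; within the scatter), so the second core, like the first, shows no shift attributable to the change. Set side by side, the two steps agree: the same change on two cores in this assay, a 1.0-fold lower number (0.01 log units; within the scatter) from compound 2 to compound 1 and a 1.1-fold lower number (0.03 log units; within the scatter) from compound 3 to compound 4, 1.1-fold (0.02 log units) apart, within the scatter of two such steps. This supports carrying the swap between these two cores without a readable effect on this read-out, but it does not show that the same would hold on any other core, and it does not show that the two groups are interchangeable in any respect beyond this one number.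

The compounds shown carry only furan-2-yl or phenyl at this place, next to the ring nitrogen, so what an amine, a carboxylic acid or a longer chain would do there remains open, as does the effect of any group other than hydroxyl and chlorine on the two flanking rings. All four numbers also come from this assay, which leaves open whether the swap stays equally silent on any other read-out.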